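Rejoining the Same Atoms on a Carbonyl Carbon

This account rests on a few compounds, and the source may have more. Where it says the series, first, only, none or still open, it means among the compounds named here.

Two compounds have been measured in a functional assay on the whole organism (arterial blood) with Rattus norvegicus as the target (on this read-out lower numbers stand for an effect already at smaller amounts and higher numbers for an effect only at larger amounts of compound), so far:
- compound 1 `Cc1nc2cnccc2n1CC1CCN(C(=O)CC(C)(O)c2ccccc2)CC1` with 0.043 mg/kg recorded
- compound 2 `Cc1nc2cnccc2n1CC1CCN(C(=O)N[C@@H](C)c2ccccc2)CC1` with 0.21 mg/kg recorded

Of these two, compound 2 has the higher number, at 0.21 mg/kg on the same read-out, and the gap to compound 1 lies beyond the usual scatter. Compound 3 `Cc1nc2cnccc2n1CC1CCN(C(=O)CN(C)c2ccccc2)CC1` has not yet been measured. It has the same atoms as compound 2, joined differently: (methyl(phenyl)amino)methyl in place of (1-phenylethyl)amino on a carbonyl carbon with (methyl(phenyl)amino)methyl in place of (1-phenylethyl)amino on a carbonyl carbon. Within the data shown here, no measured step between compounds that differ in one place is available, so the expected size rests on little. Among the measured compounds shown here, compound 1 at 0.043 mg/kg is the only other value, and it shows that a lower number is reachable with this shared core. The expected change is therefore modest and towards a lower number, within the scatter. The estimated step is a 1.8-fold lower number from compound 2 to compound 3 (0.24 log units; within the scatter) in this expectation. Compound 3 is estimated at 0.12 mg/kg with an expected range of 0.03 mg/kg to 0.45 mg/kg as its likely result.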

Compound 3, dose for 50% inhibition: 0.31 mg/kg
Beside the measured number, compound 3's estimate is 2.6-fold (0.41 log units) below it; the range from low to high includes it.
By their numbers in this assay, from the lowest: compound 1; then compounds 2 and 3 (each within the scatter of the next).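

In this assay, placing (methyl(phenyl)amino)methyl where (1-phenylethyl)amino stood, on a carbonyl carbon whose other neighbour is the amide-type nitrogen in a ring, gives a 1.5-fold higher number from compound 2 to compound 3 (0.17 log units; within the scatter). This rejoining of the same atoms removes the hydrogen-bond donor and the defined stereocentre, and the read-out does not separate the two compounds. The change at the saturated chain carbon bound to a carbonyl carbon, methyl(phenyl)amino in place of 1-hydroxy-1-phenylethyl, is a different matter, with a 7.2-fold higher number from compound 1 to compound 3 (0.86 log units; beyond the scatter), and nothing available explains either step.

The compounds shown leave open whether the gap to compound 1 follows the hydroxyl of its 1-hydroxy-1-phenylethyl group, its methyl or the carbon that carries them, as a 1-methoxy-1-phenylethyl or a plain 2-phenylethyl group on the same chain carbon would help to tell. They also leave open how the mirror-image (1-phenylethyl)amino group would read on the carbonyl carbon, and whether a longer chain to the phenyl ring would shift the number at all.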